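Swapping the chain end of compound 3

A few compounds are considered here, and "the series" means these few. Any claim that something is new, unique, unknown or untested is made for them only; others in the source may bear on it.

Measured in a functional assay on A549 cells (Homo sapiens) for inhibition, read by MTT assay, with a stated time of 72 h (a higher number here means a weaker inhibitor, a lower number a stronger inhibitor), so far
- Compound 1 `Nc1ncnc2c1c(-c1cnc3[nH]ccc3c1)nn2CCCCC(=O)NO` gives > 150000 nM as a limit
- Compound 2 `Nc1ncnc2c1c(-c1cnc3[nH]ccc3c1)nn2CCCCCCCCCC(=O)NO` gives 6550 nM
- Compound 3 `Nc1nc2cc(-c3nn(CCCCC(=O)NO)c4ncnc(N)c34)ccc2o1` gives > 100000 nM as a limit

Compound 3 has only a limit (> 100000 nM) and no exact number. The next compound to be tested is compound 4 `CNC(=O)CCCCCCCn1nc(-c2ccc3oc(N)nc3c2)c2c(N)ncnc21` and it differs in one place (3-(methylcarbamoyl)propyl in place of hydroxycarbamoyl on a saturated chain carbon, four bonds along the chain from an aromatic nitrogen) with 3-(methylcarbamoyl)propyl in place of hydroxycarbamoyl on a saturated chain carbon, four bonds along the chain from an aromatic nitrogen.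

Among the compounds with values here, one measured step bears on this change. The step of an at least 22-fold lower number from compound 1 to compound 2 (1.35 log units; beyond the scatter) put 5-(hydroxycarbamoyl)pentyl in place of hydroxycarbamoyl at that same place, on the core of compound 1. Within the data shown here, that step made the chain longer and kept the hydroxycarbamoyl end, whereas this change removes that end, and no measured compound shows what removing it does. Only part of the large earlier gain is therefore expected here, and another limit would be no surprise. The expected step is an at least 2.5-fold lower number from compound 3 to compound 4 (0.39 log units; beyond the scatter) in this assay and it remains uncertain. For compound 4 the estimated value is about 40000 nM with an expected range from 8000 nM to 150000 nM in this estimate.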

Compound 4, half-maximal inhibitory concentration: 8360 nM
Compound 4: middle estimate off by 4.8-fold (0.68 log units), on the high side; measured number inside the range.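

Replacing hydroxycarbamoyl with 3-(methylcarbamoyl)propyl at this place gives, in this assay, an at least 11-fold lower number from compound 3 to compound 4 (1.07 log units; beyond the scatter), so a large drop in the number does not depend on keeping the hydroxycarbamoyl end. The only earlier gain at this place, an at least 22-fold lower number from compound 1 to compound 2 (1.35 log units; beyond the scatter), came with a longer chain that still ended in hydroxycarbamoyl, so it could not show this. Compound 3 gives > 100000 nM, which is a limit and not a number, so the step gives only the smallest size the change can have: the limit of > 100000 nM in this assay, at which 1 of the 4 values shown sits.

The change from compound 3 to compound 4 lengthens the chain and swaps its end in a single move, so the compounds shown do not tell how much of the gain belongs to each. A hydroxycarbamoyl end on the longer chain of compound 4, and other chain ends on that same chain, such as a carboxylic acid or an amine, would separate the two and show whether the methylcarbamoyl end matters at all.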